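The compounds below may be only part of what the source reports. "The series", "measured", "known", "first", "only" and "open" are said of these compounds alone.

Of the compounds shown here, three built on one shared core have been measured in an in vitro assay on HEK385-7 cells for displacement of a labelled ligand from prostaglandin D2 receptor 2 (Homo sapiens); a higher number here means a weaker inhibitor, a lower number a stronger inhibitor. Compound 1 `COc1ccc(C(c2ccccn2)c2nc(-c3ccc(Cl)cc3)c(CC(=O)O)s2)cc1` gives 61 nM, compound 2 `O=C(O)Cc1sc(C(c2ccccc2)c2ccccc2)nc1-c1ccc(F)c(F)c1` gives 4.1 nM, and compound 3 `N#Cc1cc(-c2nc(C(c3ccc(F)cc3)c3ccc(F)cc3)sc2CC(=O)O)ccc1F` gives 57 nM. Among these three numbers compound 3 holds the second highest; its value and that of compound 1 lie within the scatter of each other, so no order between the two can be claimed, while the gap from compound 3 to compound 2 lies beyond the scatter. Compound 4 `Nc1cc(-c2nc(C(c3ccc(F)cc3)c3ccc(F)cc3)sc2CC(=O)O)cc(F)n1` has not yet been measured. It differs from compound 3 in one place: 2-amino-6-fluoropyridin-4-yl in place of 3-cyano-4-fluorophenyl on an aromatic carbon. For the measured compounds named here, no measured pair in this set shows that exchange, so there is no earlier step to lean on. The expectation is a step of a 1.4-fold higher number from compound 3 to compound 4 (0.15 log units; within the scatter), a shift that may well stay within the scatter. Compound 4 is therefore estimated at 80 nM, with a range from 25 nM to 250 nM.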

Compound 4, half-maximal inhibitory concentration: 220 nM
Compound 4: middle estimate off by 2.8-fold (0.44 log units), on the low side; the measured number falls inside the stated range.
By their numbers in this assay, from the lowest: compound 2; then compounds 3 and 1 (each within the scatter of the next); then compound 4.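

In this assay, the group on the aromatic carbon next to the ring nitrogen cannot be exchanged freely: putting 2-amino-6-fluoropyridin-4-yl in place of 3-cyano-4-fluorophenyl gives a 3.9-fold higher number from compound 3 to compound 4 (0.59 log units; beyond the scatter) in a change the data class as modest. For the compounds shown here, the earlier compounds offered no pair differing in one place, so this is the first sign that this position alone can shift the number beyond the usual scatter. No measurement at hand offers an explanation for the step.

Going by these compounds alone, the exchange removes the nitrile and brings in a ring nitrogen and an amine all at once, so the single step cannot show which of these changes carries the effect. Also open, from the compounds shown here alone, is where a group such as 2-aminopyridin-4-yl without the fluorine, or plain pyridin-4-yl, would fall relative to compound 3 and compound 4.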